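One Amide Substituent Changed Again

The source may report more compounds than this note shows. Statements on the series, on what has been measured and on what is new or still open speak of the compounds shown alone.

In a functional assay on BXPC-3 cells (Homo sapiens) for antiproliferative activity, read by MTT assay, with a stated time of 24 h (a lower number here means a stronger inhibitor, a higher number a weaker inhibitor), compound 2 `CCn1c(C(=O)NC(C)(C)CO)ccc1C(CC)(CC)c1ccc(OCS(=O)(=O)c2ccccc2)c(C)c1` gives 18300 nM, the higher of the two numbers, while compound 1 `CCN(CC)CCNC(=O)c1ccc(C(CC)(CC)c2ccc(OCS(=O)(=O)c3ccccc3)c(C)c2)n1CC` gives 6270 nM. Compound 3 `CCn1c(C(=O)N[C@@H](CO)C(C)C)ccc1C(CC)(CC)c1ccc(OCS(=O)(=O)c2ccccc2)c(C)c1` keeps the core of compound 2 and alters only the group on an amide-type nitrogen: 1-(hydroxymethyl)-2-methylpropyl in place of 1-(hydroxymethyl)-1-methylethyl on an amide-type nitrogen. Within the data shown here, the one measured step at this place, a 2.9-fold higher number from compound 1 to compound 2 (0.47 log units; beyond the scatter), was modest, and it involved the more different 2-(diethylamino)ethyl group. A smaller change is therefore expected in this assay, an estimated 1.1-fold lower number from compound 2 to compound 3 (0.06 log units; within the scatter), with no step beyond the scatter. Compound 3 is estimated at 16000 nM, within a range of 7500 nM to 32000 nM.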

Compound 3, half-maximal inhibitory concentration: 13200 nM
Compound 3: middle estimate off by 1.2-fold (0.08 log units), on the high side; the measured number falls inside the stated range.
By their numbers in this assay, from the lowest: compound 1; then compounds 3 and 2 (each within the scatter of the next).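

In this assay, 1-(hydroxymethyl)-2-methylpropyl in place of 1-(hydroxymethyl)-1-methylethyl gives a 1.4-fold lower number from compound 2 to compound 3 (0.14 log units; within the scatter), so this position does not separate these two hydroxymethyl-bearing groups. The gap to the 2-(diethylamino)ethyl group persists with the second of them, at a 2.1-fold higher number from compound 1 to compound 3 (0.32 log units; beyond the scatter), and so both hydroxymethyl-bearing groups give higher numbers than compound 1. Nothing available here explains these numbers.

Going by these compounds, how a primary amine or a longer chain on this amide-type nitrogen would read remains open. So does the opposite stereocentre of compound 3.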